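The source may hold more compounds than are shown below. What is called first, only, known or untested is meant among the compounds shown, and "the series" means these compounds.

In a functional assay on Bel-7402 cells (Homo sapiens) for inhibition, read by MTT assay, with a stated time of 24 h, tested at 10 ug/mL (a lower number here means less inhibition of growth, a higher number more inhibition of growth at the concentration tested), compound 1 `O=C(CCCCC(S)CCS)Nc1ccccc1` gives 3.72%, and compound 3 `O=C(CCCCC(S)CCS)Nc1cccc(C(F)(F)F)c1` gives 1.21%. Among the compounds with values here, these two values lie within the scatter of each other, so compound 1 stands level with the only other compound that has a number. Within the data shown here, compound 2 `O=C(CCCCC(S)CCS)Nc1ccccc1Cl` is reported as "not active" (no number reported), with no number, so it offers no measured step to compare.

The open question is compound 4 `O=C(CCCCC(S)CCS)Nc1ccc(OC(F)(F)F)cc1`. Its change from compound 1 is trifluoromethoxy in place of hydrogen on an aromatic carbon, para to a large group.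

Among the measured compounds shown here, one measured step bears on this change, as it also puts a fluorinated group in place of hydrogen on the same ring: a number 2.5 percentage points lower from compound 1 to compound 3 (within the scatter). That is a single small step, and the group and its place differ, so it is only a rough guide. No step beyond the scatter is expected, in either direction.

The expected change is a number 0.7 percentage points lower from compound 1 to compound 4 (within the scatter), which stays within the scatter.

Compound 4 is estimated at 3%, with an expected range from 0% to 12%.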

Compound 4, percent growth inhibition at one concentration: 14.2%
Compound 4: middle estimate off by 11.2 percentage points, on the low side; the measured number lies above the stated range.
By their numbers in this assay, from the lowest: compounds 3 and 1 (each within the scatter of the next); then compound 4.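

In this assay, trifluoromethoxy para to a large group gives a number 10.5 percentage points higher from compound 1 to compound 4 (beyond the scatter) and is the first step among these compounds to clear the usual scatter. The trifluoromethyl step, a number 2.5 percentage points lower from compound 1 to compound 3 (within the scatter), could not be told from scatter, so a fluorinated group on this ring does not always shift the number. Nothing measured here explains the rise seen with compound 4.

The compounds shown do not separate the effect of the group from that of its place, since no compound carries trifluoromethoxy anywhere else on the ring or trifluoromethyl para to a large group. Going by these compounds, it also remains open whether a methoxy group, which lacks the three fluorines, or an amine at this same place would give a similar step.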